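Dropping One Hydroxy Group: Compound 2 to Compound 3

The source may report more compounds than this note shows. Statements on the series, on what has been measured and on what is new or still open speak of the compounds shown alone.

Compound 1 `COc1cccc(/C=C2\CCC/C(=C\c3cc(OC)c(OC)c(OC)c3)C2=O)c1OC` gives 2600 nM in a functional assay on LoVo cells (Homo sapiens) for antiproliferative activity, read by MTT assay, with a stated time of 72 h; a lower number here means a stronger inhibitor, a higher number a weaker inhibitor.
Compound 2 `COc1cc(/C=C2\CCC/C(=C\c3ccc(O)c(O)c3)C2=O)cc(OC)c1OC` gives 2700 nM in this assay.

Going by the values given here, compound 2 holds the higher of the two numbers so far, yet the step of a 1.0-fold higher number from compound 1 to compound 2 (0.02 log units; within the scatter) lies within the scatter, so the two compounds cannot be told apart on these data. Compound 3 `COc1cc(/C=C2\CCC/C(=C\c3cccc(O)c3)C2=O)cc(OC)c1OC` differs from compound 2 in one place: hydrogen in place of hydroxy on an aromatic carbon. Among the compounds with values here, no measured step removes a single hydroxy group while leaving the rest of the molecule unchanged; the only step available, from compound 1 to compound 2, exchanges an entire ring substituent pattern and still moved the number by an amount within the scatter. With that precedent, the step from compound 2 to compound 3 in this assay is expected to be small, a 1.2-fold higher number from compound 2 to compound 3 (0.07 log units; within the scatter), leaning toward a slightly higher number. Compound 3 is therefore estimated at 3200 nM, with a range from 1300 nM to 8000 nM.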

Compound 3, half-maximal inhibitory concentration: 4800 nM
For compound 3 the middle estimate is 1.5-fold (0.18 log units) below the measured one; measured number inside the range.
By their numbers in this assay, from the lowest: compounds 1, 2 and 3 (each within the scatter of the next).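

Going by these compounds alone, this is the first step that removes a single hydroxy group and leaves the rest of the molecule unchanged: in this assay, going from 3,4-dihydroxyphenyl to 3-hydroxyphenyl, with hydrogen entering para to a large group, gives (a 1.8-fold higher number from compound 2 to compound 3 (0.25 log units; within the scatter)). So these data do not show that this hydroxy group matters for the read-out, and the wider exchange of 2,3-dimethoxyphenyl for 3-hydroxyphenyl also stays within the scatter (a 1.8-fold higher number from compound 1 to compound 3 (0.27 log units; within the scatter)). No independent measurement is available to explain how close these numbers lie.

As far as these compounds go, it remains open whether a different group at this position, such as an amine or a carboxylic acid, would shift the number beyond the scatter. The same question applies to the remaining hydroxy group of compound 3.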